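Replacing the 3-fluoro-4-methoxyphenyl group of compound 1

The compounds below may be only part of what the source reports. "The series", "measured", "known", "first", "only" and "open" are said of these compounds alone.

compound 1 `COc1ccc(-c2cncnc2-c2cc(OC)c(OC)c(OC)c2)cc1F` with 3340 nM
compound 2 `CCOc1ccc(-c2cncnc2-c2cc(OC)c(OC)c(OC)c2)cc1F` with 800 nM
compound 3 `COc1cc(-c2ncncc2-c2ccc(OC(C)C)cc2)cc(OC)c1OC` with 9970 nM

In a functional assay on SiHa cells (Homo sapiens) for antiproliferative activity, read by CCK-8 assay, with a stated time of 72 h (on this read-out lower numbers stand for stronger inhibition and higher numbers for weaker inhibition), compound 1 gives 3340 nM and holds the second highest of the three numbers. On the higher side, and nearest to it, compound 3 stands at 9970 nM. On the lower side, and furthest from it, compound 2 stands at 800 nM. Both gaps lie beyond the scatter.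

The next compound, compound 4 `COc1ccc(-c2cncnc2-c2cc(OC)c(OC)c(OC)c2)nc1`, has not yet been measured. It carries 5-methoxypyridin-2-yl in place of 3-fluoro-4-methoxyphenyl on an aromatic carbon.

Going by the values given here, only one measured step touches this group: a 4.2-fold lower number from compound 1 to compound 2 (0.62 log units; beyond the scatter). That step is modest and comes from methyl in place of hydrogen on a saturated chain carbon bound to an oxygen on an aromatic ring. It does not exchange the ring itself, so no measurement bears directly on this replacement. Among the compounds with values here, it shows only that a small change within this group can move the number beyond the scatter.

A step of similar modest size is therefore expected in this assay, tentatively towards a higher number, although the data do not fix the direction. The expected step is a 1.6-fold higher number from compound 1 to compound 4 (0.22 log units; within the scatter). For compound 4 the estimated value is 5500 nM, with an expected range from 1500 nM to 20000 nM.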

Compound 4, half-maximal inhibitory concentration: 1750 nM
Beside the measured number, compound 4's estimate is 3.1-fold (0.50 log units) above it; the range from low to high includes it.
By their numbers in this assay, from the lowest: compound 2; then compounds 4 and 1 (each within the scatter of the next); then compound 3.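

In this assay, the earlier step altered only the chain on the oxygen, whereas this result exchanges the aromatic ring itself, and it gives a 1.9-fold lower number from compound 1 to compound 4 (0.28 log units; within the scatter), which lies within the scatter. At this aromatic carbon, ortho to a large group, the six-membered ring of carbon only can thus give way to a six-membered aromatic ring with 1 hetero atom without a change that can be told from the scatter, even though the fluorine leaves and the count of hydrogen-bond acceptors goes from 1 to 2. Nothing available explains why the number holds across this exchange.

The loss of the fluorine and the entry of the ring nitrogen arrive together in this one change, so the compounds shown cannot separate them, and they also leave open whether the step from methoxy to ethoxy seen between compound 1 and compound 2 would recur on the 5-methoxypyridin-2-yl ring. On these data alone, how an amine or a carboxylic acid in place of the methoxy on this ring would read in this assay also remains open.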